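Swapping the pyridyl arm for thiophene in compound 1

This account rests on a few compounds, and the source may have more. Where it says the series, first, only, none or still open, it means among the compounds named here.

Measured compounds: compound 1 `Clc1ccc(COc2ccc(/C=C/C(/C=C/c3ccccn3)=N/Oc3ncnc4ccccc34)cc2)cc1`, 91.2%; compound 2 `Clc1ccc(COc2ccc(/C=C/C(/C=C/c3ccccn3)=N/Oc3ncnc4cc(Cl)ccc34)cc2)cc1`, 67.4%; compound 3 `Cc1cccc(COc2ccc(/C=C/C(/C=C/c3ccccn3)=N/Oc3ncnc4ccccc34)cc2)c1`, 69.2%.

In a functional assay on SMMC-7721 cells (Homo sapiens) for inhibition, read by MTT assay, with a stated time of 72 h, tested at 1 uM (on this read-out lower numbers stand for a weaker effect and higher numbers for a stronger effect at the one concentration tested), compound 1 gives the highest of the three numbers; compound 3 sits a number 22 percentage points lower from compound 1 to compound 3 (beyond the scatter), and compound 2 sits a number 23.8 percentage points lower from compound 1 to compound 2 (beyond the scatter). Compound 4 `Clc1ccc(COc2ccc(/C=C/C(/C=C/c3cccs3)=N/Oc3ncnc4ccccc34)cc2)cc1` differs from compound 1 by thiophen-2-yl in place of pyridin-2-yl on a double-bonded chain carbon bound to a double-bonded chain carbon. Neither measured step touches that part of the structure, so nothing bears directly on it; what the two steps do show is that each change made so far to compound 1 cost a modest amount in this assay. A similar, smaller loss is therefore expected here, so that compound 4 is estimated to give 78% (range 55% to 93%), a step of a number 13.2 percentage points lower from compound 1 to compound 4 (beyond the scatter).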

Compound 4, a percentage reported as inhibition, at one concentration (the size of the read-out at that concentration, not a potency): 89.3%
Estimate against measurement, compound 4: 11.3 percentage points below; low and high end bracket the measured number.
By their numbers in this assay, from the lowest: compounds 2 and 3 (each within the scatter of the next); then compounds 4 and 1 (each within the scatter of the next).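

In this assay the change from pyridin-2-yl to thiophen-2-yl gives a number 1.9 percentage points lower from compound 1 to compound 4 (within the scatter) and so, unlike the two changes elsewhere on compound 1, costs nothing that can be told from the scatter. At this place on the chain, a six-membered aromatic ring with nitrogen and a five-membered aromatic ring with sulfur therefore read alike at the one concentration tested. Nothing at hand explains this likeness.

On these data alone, whether plain phenyl, furan-2-yl or a saturated ring such as piperidin-1-yl would read the same here remains open. So does how thiophen-2-yl would behave alongside the chloro or 3-methylphenyl changes.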